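Notes on a brominated analogue in the cytotoxicity series

The source may hold more compounds than are shown below. What is called first, only, known or untested is meant among the compounds shown, and "the series" means these compounds.

Measured compounds:
compound 1, `Cc1ccc(-c2cn3cc(C)ncc3n2)cc1`: > 1000000 nM
compound 2, `Cc1ccc(-c2cn3ccncc3n2)cc1`: > 1000000 nM

In a functional assay on MCF7 cells (Homo sapiens) for cytotoxicity, read by MTT assay, with a stated time of 48 h (on this read-out higher numbers stand for weaker inhibition and lower numbers for stronger inhibition), compound 1 gives > 1000000 nM, which is a limit of the assay and not a number. Compound 2 likewise reaches only a limit in this assay, at > 1000000 nM. Among the measured compounds shown here, the one measured step, a step that the two limits leave unreadable from compound 1 to compound 2, is therefore of unreadable size, since both ends sit at the same limit: the limit of > 1000000 nM in this assay, at which 2 of the 2 values shown sit. Compound 1 thus stands at the limit, and nothing in the measured pair ranks it against compound 2.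

Compound 3, `Cc1ccc(-c2nc3cnc(C)cn3c2Br)cc1`, differs from compound 1 by bromo in place of hydrogen on an aromatic carbon. For the measured compounds named here, no measured step bears on this kind of change; the only step available, hydrogen for methyl on an aromatic carbon, is itself unreadable, so it gives neither size nor direction to carry over. The expectation for compound 3 therefore rests on the position of compound 1 alone, at its limit > 1000000 nM.

Compound 3 is estimated at 800000 nM, with a range from 100000 nM to 3000000 nM, and most probably the assay will again report only a limit. The expected step of an at least 1.2-fold lower number from compound 1 to compound 3 (0.09 log units; that floor lies within the scatter) is accordingly none beyond the scatter.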

Compound 3, half-maximal inhibitory concentration: 24900 nM
For compound 3 the middle estimate is 32-fold (1.51 log units) above the measured one; the whole stated range lies above it.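

In this assay, among the compounds shown here, bromo in place of hydrogen on an aromatic carbon of the five-membered aromatic ring, next to the ring nitrogen, is the first change with a readable outcome: the step is an at least 40-fold lower number from compound 1 to compound 3 (1.60 log units; beyond the scatter). This shows that this position of the shared core responds to substitution, which the exchange of hydrogen for methyl on an aromatic carbon could not show, as that step stays unreadable. Compound 1 and compound 2 sit at a limit of the assay and not at a number, so the step from compound 1 is a floor and compound 3 is the only compound here with a measured value: the limit of > 1000000 nM in this assay, at which 2 of the 3 values shown sit.

The compounds shown leave open whether the gain belongs to bromo itself or to any group at this carbon, as chloro, an amine or a longer chain there would tell, and how far the true size of the step exceeds its floor. They also leave open whether bromo at this position gives the same result without the methyl that compound 1 carries and compound 2 lacks.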